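Swapping bromo for methoxy on a second core

The compounds below may be only part of what the source reports. "The series", "measured", "known", "first", "only" and "open" are said of these compounds alone.

Compound 1 `O=C(Nc1ccc(Oc2ccnc3[nH]ccc23)c(F)c1)c1cc2cccnc2n(-c2ccc(Br)cc2)c1=O` and compound 2 `COc1ccc(-n2c(=O)c(C(=O)Nc3ccc(Oc4ccnc5[nH]ccc45)c(F)c3)cc3cccnc32)cc1` share one core, while compound 3 `Cn1ccc2c(Oc3ccc(NC(=O)c4cc5cccnc5n(-c5ccc(Br)cc5)c4=O)cc3)ccnc21` and compound 4 `COc1ccc(-n2c(=O)c(C(=O)Nc3ccc(Oc4ccnc5c4ccn5C)cc3)cc3cccnc32)cc1` share another; how the two cores differ is not broken down here. In a functional assay on A549 cells (Homo sapiens) for antiproliferative activity, read by MTT assay, with a stated time of 72 h (a higher number here means a weaker inhibitor, a lower number a stronger inhibitor), compound 1 gives 210 nM, compound 2 gives 610 nM, and compound 3 gives 680 nM. The change from compound 1 to compound 2 is methoxy in place of bromo on an aromatic carbon and it produced a 2.9-fold higher number from compound 1 to compound 2 (0.46 log units; beyond the scatter). The same change, (methoxy in place of bromo on an aromatic carbon), takes compound 3 to compound 4, which has not yet been tested in this assay. For the measured compounds named here, the place of the change reads the same on both cores, so the earlier step is the only guide, and it points toward a weaker inhibitor. For compound 4 I expect a step of about a 2.5-fold higher number from compound 3 to compound 4 (0.40 log units; beyond the scatter), a little smaller than the earlier one since a single step on a different core is a thin basis. My estimate for compound 4 is therefore 1700 nM, with a likely range from 700 nM to 4500 nM.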

Compound 4, half-maximal inhibitory concentration: 3460 nM
The estimate for compound 4 lay 2.0-fold (0.31 log units) below the measured number, within the range that was stated.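

In this assay, methoxy in place of bromo on the second core gave a 5.1-fold higher number from compound 3 to compound 4 (0.71 log units; beyond the scatter), so the change from 4-bromophenyl to 4-methoxyphenyl pointed toward a weaker inhibitor on both cores. Set side by side, the two steps cannot be told apart in size, so the effect of the change looks much the same on these two cores: the same change on two cores in this assay, a 2.9-fold higher number (0.46 log units; beyond the scatter) from compound 1 to compound 2 and a 5.1-fold higher number (0.71 log units; beyond the scatter) from compound 3 to compound 4, 1.8-fold (0.24 log units) apart, within the scatter of two such steps This shows that the change carried over in direction and, as far as the scatter allows, in size, but two pairs are a small sample, and they do not show that it would hold on any other core or explain why methoxy gives the higher number.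

The compounds shown leave open how other groups in the same place on that aromatic ring, such as chloro, an amine or a carboxylic acid, would compare with bromo and methoxy. They also leave open whether the same step would appear on a third core.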